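Benzothiophene amide on the chlorophenylpiperidine core

A few compounds are considered here, and "the series" means these few. Any claim that something is new, unique, unknown or untested is made for them only; others in the source may bear on it.

Of the compounds shown here, three have numbers so far in an assay on THP-1 cells for displacement of a labelled ligand from C-C chemokine receptor type 1 (Homo sapiens); on this read-out higher numbers stand for weaker inhibition and lower numbers for stronger inhibition. Compound 1 `CC[C@@H](C)[C@@H](NC(=O)c1ccccc1)C(=O)N1CCC(c2ccc(Cl)cc2)CC1` gives 45 nM, compound 3 `CC[C@@H](C)[C@@H](NC(=O)CCc1ccccc1)C(=O)N1CCC(c2ccc(Cl)cc2)CC1` gives 66 nM and compound 2 `Cc1ccccc1C(=O)N[C@@H](C(=O)N1CCC(c2ccc(Cl)cc2)CC1)C(C)C` gives 32 nM. Within the data shown here, the single step between compounds that differ in one place is a 1.5-fold higher number from compound 1 to compound 3 (0.17 log units; within the scatter). Compound 2 has the lowest of the three numbers; its gap to compound 1 is within the scatter, and only its gap to compound 3 lies beyond it, so compound 2 cannot be set apart from compound 1 on the present data.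

Compound 4 `CC(C)[C@@H](NC(=O)c1cc2ccccc2s1)C(=O)N1CCC(c2ccc(Cl)cc2)CC1` is not yet measured. The change is 1-benzothiophen-2-yl in place of 2-methylphenyl on a carbonyl carbon. Among the measured compounds shown here, no measured pair repeats this exchange; the only step that touches the group on the carbonyl carbon is the phenethyl-for-phenyl exchange from compound 1 to compound 3, which stayed within the scatter. On that basis the expected step of a 1.1-fold lower number from compound 2 to compound 4 (0.03 log units; within the scatter) is none beyond the scatter, with the range kept wide, as a change of this kind has not been tested in the series. Compound 4 is therefore estimated at 30 nM, within 10 nM to 90 nM in this assay.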

Compound 4, half-maximal inhibitory concentration: 58 nM
Beside the measured number, compound 4's estimate is 1.9-fold (0.29 log units) below it; the measured number falls inside the stated range.
By their numbers in this assay, from the lowest: compounds 2, 1, 4 and 3 (each within the scatter of the next, the first and the last beyond it).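

Exchanging 2-methylphenyl for 1-benzothiophen-2-yl on a carbonyl carbon whose other neighbour is an amide-type nitrogen gives a 1.8-fold higher number from compound 2 to compound 4 (0.26 log units; within the scatter) in this assay and leaves the two compounds indistinguishable on this read-out. Among these compounds, this is the first one-place step to put a second aromatic ring, a sulfur atom and a hydrogen-bond acceptor into this group, taking it from 7 heavy atoms to 9, and the number stays within the scatter. With a 1.5-fold higher number from compound 1 to compound 3 (0.17 log units; within the scatter), both one-place exchanges at this group now lie within the scatter, and no data on any property of these groups bear on the result.

The compounds shown leave open whether a group carrying an amine or a carboxylic acid on this carbonyl carbon would give a step beyond the scatter, as all four groups here are built from carbon and, in compound 4, sulfur alone. They also leave open whether 1-benzothiophen-2-yl gives the same result on the core of compound 1, and whether a 1-benzofuran-2-yl group, with oxygen in place of sulfur, would match it.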